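Shifting the Hydroxyl Around the Pyridine Amide

The compounds below may be only part of what the source reports. "The series", "measured", "known", "first", "only" and "open" are said of these compounds alone.

Measured compounds:
compound 1, `CN1C(C(=O)Nc2ncccc2O)=C(O)c2ccccc2S1(=O)=O`: 41%
compound 2, `CN1C(C(=O)Nc2cccc(O)n2)=C(O)c2ccccc2S1(=O)=O`: 40%

In a functional assay on the whole organism for inhibition, with Rattus norvegicus as the target, with a stated time of 4 h, at a dose of 33 mg/kg by the oral route (on this read-out higher numbers stand for more inhibition at the one dose given (going by the name of the read-out) and lower numbers for less inhibition), compound 1 gives 41%, and in this assay compound 2 gives 40%. Among the compounds with values here, compound 2 thus holds the lowest of the two numbers, but its nearest neighbour is compound 1, and the single measured step, a number 1 percentage points lower from compound 1 to compound 2 (within the scatter), lies within the scatter, so the two values cannot be told apart.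

Compound 3, `CN1C(C(=O)Nc2cc(O)ccn2)=C(O)c2ccccc2S1(=O)=O`, is the next member of the series. Its difference from compound 2 is counted as 4-hydroxypyridin-2-yl in place of 6-hydroxypyridin-2-yl on an amide-type nitrogen. Within the data shown here, the one measured step that bears on this change is the earlier move of the hydroxyl around the same ring, a number 1 percentage points lower from compound 1 to compound 2 (within the scatter), which produced no shift beyond the scatter. On that basis the new position of the hydroxyl in compound 3 is expected to give a step of no change at the digits printed from compound 2 to compound 3 (within the scatter), that is, none beyond the scatter in either direction. Compound 3 is therefore estimated at 40%, with a range from 28% to 52%.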

Compound 3, a percentage reported as inhibition, in the whole organism at one dose (the size of the read-out at that dose, not a potency): 24%
For compound 3 the middle estimate is 16 percentage points above the measured one; measured number below the stated range.
By their numbers in this assay, from the lowest: compound 3; then compounds 2 and 1 (each within the scatter of the next).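

Moving the hydroxyl to give 4-hydroxypyridin-2-yl on the amide-type nitrogen is the first change in this series to register in this assay, with a number 16 percentage points lower from compound 2 to compound 3 (beyond the scatter) and a number 17 percentage points lower from compound 1 to compound 3 (beyond the scatter). The position of the hydroxyl on this group therefore matters, which the comparison of 3-hydroxypyridin-2-yl with 6-hydroxypyridin-2-yl alone did not reveal, and it matters even though the groups compared have the same atoms and the same counts of hydrogen-bond donors and acceptors. Nothing in the information available explains why this one arrangement stands apart from the other two.

As far as these compounds go, it remains open whether the hydroxyl itself is what counts at this place, since a methoxy group or an amine on the same 2-pyridyl attachment would test whether the 4-hydroxypyridin-2-yl result is specific to the hydroxyl. Also open, from the compounds shown here alone, is whether the same separation would hold at other doses and times, as these numbers give the size of the read-out at a single dose and not a potency.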